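Carbamoylmethyl ester in place of the phenoxyethyl ester

A few compounds are considered here, and "the series" means these few. Any claim that something is new, unique, unknown or untested is made for them only; others in the source may bear on it.

Compound 3 `CCOc1cc(NC(=O)C2(NC(=O)c3ccc4c(C5CCCC5)c(-c5ncc(Cl)cn5)n(C)c4c3)CCC2)ccc1/C=C/C(=O)OCCOc1ccccc1` is one of the longer-lived members of this small set. In an ADME assay (liver) for pharmacokinetics, with Liver microsome (Homo sapiens) as the target, using microsomes (on this read-out lower numbers stand for a shorter-lived compound and higher numbers for a longer-lived compound), compound 3 gives > 5 h, which is a limit of the assay rather than a number. Compound 2 `CCCOC(=O)/C=C/c1ccc(NC(=O)C2(NC(=O)c3ccc4c(C5CCCC5)c(-c5ncc(Cl)cn5)n(C)c4c3)CCC2)cc1OCC` reaches the same limit, giving > 5 h in this assay. Compound 1 `CCOc1cc(NC(=O)C2(NC(=O)c3ccc4c(C5CCCC5)c(-c5ncc(Cl)cn5)n(C)c4c3)CCC2)ccc1/C=C/C(=O)OCOP(=O)(O)O`, the phosphate, stands far lower, with 0.167 h in this assay. The two measured steps out of compound 1 are both large: an at least 29-fold higher number from compound 1 to compound 2 (1.47 log units; beyond the scatter) and an at least 29-fold higher number from compound 1 to compound 3 (1.47 log units; beyond the scatter). The step between the two esters, a step that the two limits leave unreadable from compound 2 to compound 3, cannot be read, because the limit of > 5 h in this assay, at which 2 of the 3 values shown sit, hides any gap between them.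

Compound 4 `CCOc1cc(NC(=O)C2(NC(=O)c3ccc4c(C5CCCC5)c(-c5ncc(Cl)cn5)n(C)c4c3)CCC2)ccc1/C=C/C(=O)OCC(N)=O` differs from compound 3 in one place: carbamoyl in place of phenoxymethyl on a saturated chain carbon bound to an oxygen next to a carbonyl group. For the measured compounds named here, no measured step exchanges one ester group for another with a readable size, so the expectation for compound 4 rests on the large steps from compound 1 and the limit reached by compound 3. Going by the values given here, the carbamoylmethyl group has no precedent here, and the estimate is therefore wide. Compound 4 is expected to sit below the limit, at an estimated 2 h with a range from 0.5 h to 5 h, which means an expected step of an at least 2.5-fold lower number from compound 3 to compound 4 (0.39 log units; beyond the scatter).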

Compound 4, half-life: 0.983 h
The estimate for compound 4 lay 2.0-fold (0.31 log units) above the measured number, within the range that was stated.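

In this assay, the ester position no longer reads as a simple contrast between the phosphate and esters that reach the limit of the assay. Carbamoyl in place of phenoxymethyl gives an at least 5.0-fold lower number from compound 3 to compound 4 (0.70 log units; beyond the scatter), and carbamoyl in place of ethyl gives an at least 5.0-fold lower number from compound 2 to compound 4 (0.70 log units; beyond the scatter), so a change at this one place can bring an ester well down from the limit, and both steps give only the smallest size the gap can have. Compound 4 still stands clear of the phosphate, with a 5.9-fold higher number from compound 1 to compound 4 (0.77 log units; beyond the scatter), which places the carbamoylmethyl ester at a level between compound 1 and the two esters at the limit, so that this position shows an intermediate level as well as the two extremes.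

The gap between compound 2 and compound 3 cannot be read, and the true size of their steps to compound 4 stays open, because both sit at the same limit: the limit of > 5 h in this assay, at which 2 of the 4 values shown sit. Whether an amine or a longer chain on this saturated chain carbon would fall nearer compound 1, nearer compound 4, or at the limit remains open, as does what in the carbamoyl group accounts for the drop.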